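Ethenyl linker in place of direct amide: compound 3

The source may report more compounds than this note shows. Statements on the series, on what has been measured and on what is new or still open speak of the compounds shown alone.

Two compounds have numbers in a functional assay on HepG2 cells (Homo sapiens) for antiproliferative activity, read by CCK-8 assay, with a stated time of 72 h, tested at 8 uM; on this read-out higher numbers stand for a stronger effect at the one concentration tested and lower numbers for a weaker effect. Compound 2 `Nc1ccccc1NC(=O)c1ccc(COCNc2nc(Nc3ccccc3)c3ncn(C4CCCC4)c3n2)cc1` gives 66.9%, the higher of the two, and compound 1 `Nc1ccccc1NC(=O)/C=C/c1ccc(COCNc2nc(Nc3cccc(Cl)c3)c3ncn(C4CCCC4)c3n2)cc1` gives 14.8% in this assay, far below compound 2. Going by the values given here, no measured pair differs in a single place, so no step size is known. Compound 3 `Nc1ccccc1NC(=O)/C=C/c1ccc(COCNc2nc(Nc3ccccc3)c3ncn(C4CCCC4)c3n2)cc1` differs from compound 2 by 2-((2-aminophenyl)carbamoyl)ethenyl in place of (2-aminophenyl)carbamoyl on an aromatic carbon. Compound 1 carries the same 2-((2-aminophenyl)carbamoyl)ethenyl group and gives only 14.8%. A fall beyond the scatter is therefore expected, a number 31.9 percentage points lower from compound 2 to compound 3 (beyond the scatter). Compound 3 is estimated at 35%, within a range from 10% to 62%.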

Compound 3, a percentage reported as inhibition, at one concentration (the size of the read-out at that concentration, not a potency): 18.8%
Estimate against measurement, compound 3: 16.2 percentage points above, and the stated range covers the measured number.
By their numbers in this assay, from the lowest: compounds 1 and 3 (each within the scatter of the next); then compound 2.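

In this assay, the change to 2-((2-aminophenyl)carbamoyl)ethenyl in place of (2-aminophenyl)carbamoyl can now be read on its own, and it gives a number 48.1 percentage points lower from compound 2 to compound 3 (beyond the scatter). Hydrogen in place of chloro on an aromatic carbon gives a number 4 percentage points higher from compound 1 to compound 3 (within the scatter), so the chloro group does not separate these two compounds once the ethenyl group is present. Nothing available explains the large fall from the ethenyl group. Going by these compounds, whether a saturated ethyl chain at this position would keep the number of compound 2 remains open. So does the effect of chloro on the (2-aminophenyl)carbamoyl series.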